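The source may report more compounds than this note shows. Statements on the series, on what has been measured and on what is new or still open speak of the compounds shown alone.

Going by the values given here, in a functional assay on A549 cells (Homo sapiens) for antiproliferative activity, read by CCK-8 assay, with a stated time of 48 h (on this read-out higher numbers stand for weaker inhibition and lower numbers for stronger inhibition), compound 2 `Cc1ccccc1-c1nnc(-n2[se]c3ccccc3c2=O)s1` gives 18600 nM, one of only two numbers so far and close to compound 1 `O=c1c2ccccc2[se]n1-c1nnc(-c2ccc(F)cc2)s1`, which gives 21100 nM; the step of a 1.1-fold lower number from compound 1 to compound 2 (0.05 log units; within the scatter) lies within the scatter. Compound 3 `COc1ccccc1-c1nnc(-n2[se]c3ccccc3c2=O)s1` differs from compound 2 by methoxy in place of methyl on an aromatic carbon. Among the compounds with values here, the single measured step exchanged one aryl group for another and barely moved the read-out, and no measured step tests methoxy against methyl, so no shift beyond the scatter is expected in this assay. Compound 3 is therefore estimated at 19000 nM, between 8000 nM and 45000 nM, an expected step of a 1.0-fold higher number from compound 2 to compound 3 (0.01 log units; within the scatter).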

Compound 3, half-maximal inhibitory concentration: 3120 nM
Beside the measured number, compound 3's estimate is 6.1-fold (0.78 log units) above it, outside the stated range (below it).
By their numbers in this assay, from the lowest: compound 3; then compounds 2 and 1 (each within the scatter of the next).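

Placing methoxy in place of methyl on this aromatic carbon, ortho to a large group, gives a 6.0-fold lower number from compound 2 to compound 3 (0.78 log units; beyond the scatter) in this assay and so moves the read-out beyond the scatter, which the earlier aryl exchange did not do. This position therefore responds to a small change of group. Nothing available explains why this step is so much larger.

As far as these compounds go, it remains open whether a hydroxyl, an amine or a longer ethoxy chain here would match methoxy. From the compounds shown here alone, the effect of methoxy elsewhere on this ring also remains unknown.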